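Methylation of a phenolic hydroxy on two quinolinol cores

The source may report more compounds than this note shows. Statements on the series, on what has been measured and on what is new or still open speak of the compounds shown alone.

The series is followed in a functional assay on HL-60 cells (Homo sapiens) for antiproliferative activity; on this read-out higher numbers stand for weaker inhibition and lower numbers for stronger inhibition. Compound 1 `COc1cc2nccc(O)c2c(O)c1OC` carries two free hydroxy groups on its core; in this assay compound 1 returns only the limit > 30000 nM. Compound 2 `COc1cc2nccc(O)c2c(OC)c1OC` differs by methyl in place of hydrogen on an oxygen on an aromatic ring. In this assay compound 2 likewise returns only the limit > 30000 nM. The step that the two limits leave unreadable from compound 1 to compound 2 is therefore not readable, since both ends sit at the limit of > 30000 nM in this assay, at which 3 of the 3 values shown sit.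

Compound 3 `Cc1ccc(O)c2c(O)ccnc12` rests on a different core; the difference between the two cores is not broken down here. In this assay compound 3 also returns only the limit > 30000 nM. Among the measured compounds shown here, compound 4 `COc1ccc(C)c2nccc(O)c12` is not yet measured and differs from compound 3 by methyl in place of hydrogen on an oxygen on an aromatic ring, the same change as the one from compound 1 to compound 2, at a place described in the same words.

For the measured compounds named here, since every value shown so far rests at the limit of > 30000 nM in this assay, at which 3 of the 3 values shown sit, and the one measured instance of this change gave no readable step, compound 4 is expected to remain at or near that limit, the step that the limit leaves unreadable from compound 3 to compound 4 being the estimate. For compound 4 the expected value in this assay is 45000 nM, within 15000 nM to 150000 nM.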

Compound 4, half-maximal inhibitory concentration: > 30000 nM
Compound 4: a limit, no number; the forecaster's own chance of this, stated with the estimate: 80%; the middle value does not contradict the limit.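

In this assay compound 4 gives > 30000 nM as a limit, not a number. No step can be read between compound 3 and compound 4, since both ends are limits: the limit of > 30000 nM in this assay, at which 4 of the 4 values shown sit.

The compounds shown leave open how large the change from hydroxy to methoxy is on either core, and whether any related structure gives a numerical value.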